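Swapping 4-bromophenyl for 2-chlorophenyl on an aromatic nitrogen

A few compounds are considered here, and "the series" means these few. Any claim that something is new, unique, unknown or untested is made for them only; others in the source may bear on it.

Measured in a functional assay on MGC-803 cells (Homo sapiens) for antiproliferative activity, read by MTT assay, with a stated time of 72 h; on this read-out lower numbers stand for stronger inhibition and higher numbers for weaker inhibition:
Compound 1 `O=C(NO)c1ccc(NCc2nc(-c3ccccc3)nn2-c2ccc(Br)cc2)cc1` gives 9300 nM
Compound 2 `O=C(NO)c1ccc(NCc2nc(-c3ccc(F)cc3)nn2-c2ccccc2)cc1` gives 8960 nM
Compound 3 `O=C(NO)c1ccc(NCc2nc(-c3ccccc3Cl)nn2-c2ccccc2)cc1` gives > 20000 nM (a limit)

In this assay compound 1, at 9300 nM, lies within the scatter of compound 2. Compound 4 `O=C(NO)c1ccc(NCc2nc(-c3ccccc3)nn2-c2ccccc2Cl)cc1` differs from compound 1 by one change: 2-chlorophenyl in place of 4-bromophenyl on an aromatic nitrogen. In words, 2-chlorophenyl stands in place of 4-bromophenyl on an aromatic nitrogen. Among the compounds with values here, no measured step makes this exact change. The closest one puts 2-chlorophenyl in place of 4-fluorophenyl on an aromatic carbon: an at least 2.2-fold higher number from compound 2 to compound 3 (0.34 log units; beyond the scatter). That step ends at a limit. A rise of similar size, toward a higher number, is therefore expected here. The expected step is a 1.7-fold higher number from compound 1 to compound 4 (0.24 log units; within the scatter). For compound 4 the estimated value is 16000 nM, with an expected range from 7000 nM to 40000 nM.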

Compound 4, half-maximal inhibitory concentration: 9630 nM
Compound 4: middle estimate off by 1.7-fold (0.22 log units), on the high side; low and high end bracket the measured number.
By their numbers in this assay, from the lowest: compounds 2, 1 and 4 (each within the scatter of the next). At a limit, above all of these: compound 3.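

In this assay, the change on the aromatic nitrogen gives a 1.0-fold higher number from compound 1 to compound 4 (0.02 log units; within the scatter) and so shows that this position accepts 2-chlorophenyl as readily as 4-bromophenyl. Within the data shown here, the rise seen for 2-chlorophenyl on the aromatic carbon, an at least 2.2-fold higher number from compound 2 to compound 3 (0.34 log units; beyond the scatter) and ending at a limit, has no counterpart at this position. No measurement shown gives a reason for this result.

On these data alone, since the halogen and its place on the ring differ together here, their separate contributions remain open. So does whether an amine or a carboxylic acid on this phenyl ring would shift the number.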